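This account rests on a few compounds, and the source may have more. Where it says the series, first, only, none or still open, it means among the compounds named here.

For the measured compounds named here, in a functional assay on cells (Homo sapiens), read by thymidine incorporation (on this read-out lower numbers stand for stronger inhibition and higher numbers for weaker inhibition), compound 2 `CCOC(=O)c1cc(NCc2cccnc2)n2ncc(Br)c2n1` gives 2900 nM, the higher of the two numbers so far, while compound 1 `CCc1cc(NCc2cccnc2)n2ncc(Br)c2n1` gives 520 nM. Compound 3 `CSc1cc(NCc2cccnc2)n2ncc(Br)c2n1` carries methylsulfanyl in place of ethoxycarbonyl on an aromatic carbon. Going by the values given here, one measured step bears on this carbon, a 5.6-fold higher number from compound 1 to compound 2 (0.75 log units; beyond the scatter), where ethoxycarbonyl replaced ethyl. Among the compounds with values here, no measured compound yet carries methylsulfanyl, so this step serves only as a guide. A modest move to a lower number in this assay is expected, similar in size to that step. The estimated step is a 4.8-fold lower number from compound 2 to compound 3 (0.68 log units; beyond the scatter). Compound 3 is estimated at 600 nM, with a range of 180 nM to 2000 nM.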

Compound 3, half-maximal inhibitory concentration: 990 nM
Compound 3: the middle estimate sits 1.7-fold (0.22 log units) below what was measured, within the range that was stated.
By their numbers in this assay, from the lowest: compounds 1 and 3 (each within the scatter of the next); then compound 2.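

In this assay, replacing ethoxycarbonyl with methylsulfanyl gives a 2.9-fold lower number from compound 2 to compound 3 (0.47 log units; beyond the scatter), so the weaker inhibition seen with ethoxycarbonyl does not extend to every replacement of ethyl. Methylsulfanyl in place of ethyl gives a 1.9-fold higher number from compound 1 to compound 3 (0.28 log units; within the scatter), so these two groups cannot be told apart here, even though one brings sulfur to the ring carbon. Going by these compounds, whether an amine, a carboxylic acid or a longer alkyl chain at this carbon would side with ethyl and methylsulfanyl or with ethoxycarbonyl remains open. What sets ethoxycarbonyl apart from the other two groups also remains unexplained, with no supporting data on it.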